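The source may hold more compounds than are shown below. What is called first, only, known or untested is meant among the compounds shown, and "the series" means these compounds.

Measured so far:
compound 1, `CC(C)C[C@H](N)c1cc(C(F)(F)F)ccc1N1CCN(C(=O)CCNC2CCCCC2)CC1`: 4800 nM
compound 2, `COc1cc(Cl)ccc1C[C@@H](C)C(=O)N1CCN(c2ccc(C)cc2[C@@H](N)CC(C)C)CC1`: 8.1 nM

Among these two numbers in an assay on HEK293 cells for displacement of a labelled ligand from Melanocortin receptor 4 (Homo sapiens) (on this read-out lower numbers stand for stronger inhibition and higher numbers for weaker inhibition), compound 1 stands highest, so it is the weaker binder of the pair, far apart from compound 2. Compound 3, `Cc1cc(CC(C)C(=O)N2CCN(c3ccc(C(F)(F)F)cc3[C@@H](N)CC(C)C)CC2)ccc1Cl`, has not yet been measured. It differs from compound 1 in one place: 1-(4-chloro-3-methylbenzyl)ethyl in place of 2-(cyclohexylamino)ethyl on a carbonyl carbon. Compound 2 carries a closely related group on its carbonyl carbon and gives 8.1 nM, so a large step downwards is expected, well beyond the scatter, from compound 1 to compound 3 in this assay: a 160-fold lower number from compound 1 to compound 3 (2.20 log units; beyond the scatter). For compound 3 the estimated value is 30 nM, within a range from 5 nM to 200 nM.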

Compound 3, inhibition constant: 71 nM
Estimate against measurement, compound 3: 2.4-fold (0.37 log units) below, and the stated range covers the measured number.
By their numbers in this assay, from the lowest: compound 2; then compound 3; then compound 1.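

Replacing 2-(cyclohexylamino)ethyl with 1-(4-chloro-3-methylbenzyl)ethyl on the carbonyl carbon gives a 68-fold lower number from compound 1 to compound 3 (1.83 log units; beyond the scatter) in this assay. This first comparison of compounds differing in one place shows that this group alone can shift binding well beyond the scatter. Nothing measured here accounts for the step. The compounds shown leave open which part of the change matters: the aromatic ring, its chlorine or methyl, or the loss of the amine nitrogen. A plain benzyl group at this position could begin to separate these.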